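Shrinking the Amine on a Shared Ester Core

A few compounds are considered here, and "the series" means these few. Any claim that something is new, unique, unknown or untested is made for them only; others in the source may bear on it.

Compound 1 `CC1CCN(CC(=O)O[C@@H]2C[C@@H]3CC[C@@]2(C)C3(C)C)CC1` gives 71600 nM in an ADME assay on HEK-293T cells (Homo sapiens) for cytotoxicity, read by MTT assay, with a stated time of 48 h; on this read-out higher numbers stand for lower toxicity in this test and lower numbers for higher toxicity in this test.
Compound 2 `CC1CCN(CCCCC(=O)O[C@@H]2C[C@@H]3CC[C@@]2(C)C3(C)C)CC1` gives 73000 nM in this assay.
Compound 3 `CCOC(=O)N1CCN(CCCC(=O)O[C@@H]2C[C@@H]3CC[C@@]2(C)C3(C)C)CC1` gives 60400 nM in this assay.

All three values sit within the usual scatter of one another, so compound 1 is neither clearly more nor less toxic than compound 2 or compound 3; compound 2 lies closest to it and compound 3 furthest, both within the scatter. Compound 4 `CN(C)CCC(=O)O[C@@H]1C[C@@H]2CC[C@@]1(C)C2(C)C` has not yet been measured. It differs from compound 1 in one place: (dimethylamino)methyl in place of 4-methylpiperidin-1-yl on a saturated chain carbon bound to a carbonyl carbon. Among the measured compounds, swapping the amine and varying the chain left the read-out unchanged beyond scatter. The step of a 1.0-fold lower number from compound 1 to compound 4 (0.01 log units; within the scatter) is therefore expected to be small, in no fixed direction. Compound 4 is expected to give about 70000 nM, within 35000 nM to 140000 nM.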

Compound 4, half-maximal cytotoxic concentration: 505000 nM
For compound 4 the middle estimate is 7.2-fold (0.86 log units) below the measured one; the measured number lies above the stated range.
By their numbers in this assay, from the lowest: compounds 3, 1 and 2 (each within the scatter of the next); then compound 4.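

In this assay the group on a saturated chain carbon bound to a carbonyl carbon does matter: (dimethylamino)methyl in place of 4-methylpiperidin-1-yl gives a 7.1-fold higher number from compound 1 to compound 4 (0.85 log units; beyond the scatter) and so lower toxicity in this test. Within the data shown here, the three earlier values lay within the scatter of one another, so they gave no sign of a step this large. Nothing measured here gives a reason for it.

Still open, on these data alone, is whether the change follows from losing the ring or simply from having fewer heavy atoms. A pyrrolidin-1-yl or diethylamino group at this place would help separate the two.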